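This account rests on a few compounds, and the source may have more. Where it says the series, first, only, none or still open, it means among the compounds named here.

Of the compounds shown here, three sharing one core have been measured in a physicochemical assay for acid dissociation. Compound 1 `COc1ccc(-c2ccc3c(NCCCNCc4cccc(OC)c4O)ccnc3c2)cc1` gives 9.47 in this assay. Compound 2 `COc1cccc(CNCCCNc2ccnc3cc(C4CCCCC4)ccc23)c1O` gives 9.47 in this assay, and putting cyclohexyl in place of 4-methoxyphenyl on an aromatic carbon gave no change at the digits printed from compound 1 to compound 2 (within the scatter). Compound 3 `COc1ccc(F)cc1CNCCCNc1ccnc2cc(C3CCCCC3)ccc12` gives 9.47 in this assay; putting 5-fluoro-2-methoxyphenyl in place of 2-hydroxy-3-methoxyphenyl on a saturated chain carbon bound to an amine nitrogen gave no change at the digits printed from compound 2 to compound 3 (within the scatter). Compound 3 thus stands level with compound 1 and compound 2 at the digits shown, neither step having left the scatter.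

Compound 4 `COc1cccc(Oc2ccc3c(NCCCNCc4cc(F)ccc4OC)ccnc3c2)c1` has not yet been measured. It differs from compound 3 in one place: 3-methoxyphenoxy in place of cyclohexyl on an aromatic carbon. The measured step that bears directly on this is no change at the digits printed from compound 1 to compound 2 (within the scatter), in which the group on this same aromatic carbon was exchanged for a different ring group and the proton-giving behaviour did not move beyond the scatter. The second measured step, no change at the digits printed from compound 2 to compound 3 (within the scatter), altered a distant part of the molecule and also gave nothing. Exchanging the ring group on that aromatic carbon once more is therefore expected to give no change at the digits printed from compound 3 to compound 4 (within the scatter), no step beyond the scatter. Compound 4 is estimated to give 9.47 in this assay, within the range 9.15 to 9.8.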

Compound 4, acid dissociation constant: 9.28
Estimate against measurement, compound 4: 0.19 log units above; the measured number falls inside the stated range.
By their numbers in this assay, from the lowest: compounds 4, 1, 2 and 3 (each within the scatter of the next).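

In this assay, replacing cyclohexyl with 3-methoxyphenoxy on this aromatic carbon gave a number 0.19 log units lower from compound 3 to compound 4 (within the scatter), so a ring attached through an oxygen also leaves the reading within the scatter. This aromatic carbon has now carried three different groups across the compounds shown, 4-methoxyphenyl, cyclohexyl and 3-methoxyphenoxy, and neither exchange at this position, one made with the 2-hydroxy-3-methoxyphenyl group at the far end of the chain and one with the 5-fluoro-2-methoxyphenyl group there, has moved the number beyond the scatter. Nothing shown here offers an explanation for this result.

Going by these compounds alone, all the groups seen at this position so far contain a six-membered ring, so it remains open whether an amine, a carboxylic acid or a single chlorine atom on the same aromatic carbon would also stay within the scatter. The chain linking the shared core to the far aromatic ring is also the same throughout, which leaves open what a longer chain would do to the reading.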